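Cytotoxicity of Three Measured Analogues and One Predicted

This account rests on a few compounds, and the source may have more. Where it says the series, first, only, none or still open, it means among the compounds named here.

Compound 1, `O=C1O[C@@H](CO)CN1c1ccc(-n2cc(-c3ccccn3)cn2)c(F)c1`, in an ADME assay on HEK293-A cells (Homo sapiens) for cytotoxicity, read by MTT assay, with a stated time of 48 h (a higher number here means a weaker inhibitor, a lower number a stronger inhibitor), gives > 400 ug/mL, which is a limit of the assay. Compound 2, `COC(=O)CC1CCN(C[C@H]2CN(c3ccc(-n4cc(-c5ccccn5)cn4)c(F)c3)C(=O)O2)CC1`, gives 224 ug/mL. Compound 3, `O=C1O[C@@H](CN2CCC(c3ccc(F)cc3)CC2)CN1c1ccc(-n2cc(-c3ccccn3)cn2)c(F)c1`, gives > 400 ug/mL, again a limit of the assay.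

Compound 2 thus stands as the only numerical result among the three; the other two sit at the limit of > 400 ug/mL in this assay, at which 2 of the 3 values shown sit. Compound 4, `CC(=O)OC[C@H]1CN(c2ccc(-n3cc(-c4ccccn4)cn3)c(F)c2)C(=O)O1`, differs from compound 2 by acetoxy in place of 4-((methoxycarbonyl)methyl)piperidin-1-yl on a saturated chain carbon bound to a saturated ring carbon. Going by the values given here, two measured steps bear on this change: an at least 1.7-fold lower number from compound 1 to compound 2 (0.25 log units; that floor lies within the scatter) and an at least 1.7-fold higher number from compound 2 to compound 3 (0.25 log units; that floor lies within the scatter), each a floor lying within the scatter. Both neighbours of compound 2 at this position sit at the limit, and for compound 4 a step of a 1.8-fold higher number from compound 2 to compound 4 (0.25 log units; within the scatter) is expected, most likely back to the limit. Compound 4 is therefore estimated at 400 ug/mL, within a range of 200 ug/mL to 800 ug/mL.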

Compound 4, half-maximal inhibitory concentration: > 400 ug/mL
Compound 4: only a limit was reported; the forecaster's own chance of this, stated with the estimate: 65%; the middle value sits exactly at the limit.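

Replacing the piperidine group of compound 2 with acetoxy gives an at least 1.7-fold higher number from compound 2 to compound 4 (0.25 log units; that floor lies within the scatter) in this assay. Compound 4 carries an ester, as compound 2 does, so an ester on this side chain does not by itself give a number below the limit. Compound 4 is a third compound reported only as a limit: the limit of > 400 ug/mL in this assay, at which 3 of the 4 values shown sit.

The step between compound 1 and compound 4 cannot be read, as both values are limits. On these data alone, whether a carboxylic acid in place of the methyl ester of compound 2, or a simple amine on this saturated chain carbon, would give a number remains open.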